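Series notes: piperidinyl amide to 3-methylbenzyl swap

The source may report more compounds than this note shows. Statements on the series, on what has been measured and on what is new or still open speak of the compounds shown alone.

Measured so far:
compound 1 `COc1cc(-c2nc3cc(/C=C4\SC(=O)N(CC(=O)N5CCCCC5)C4=O)ccc3[nH]2)cc(OC)c1OC` — 3650 nM
compound 2 `COc1cc(OC)c(-c2nc3cc(/C=C4\SC(=O)N(CC(=O)N5CCCCC5)C4=O)ccc3[nH]2)cc1OC` — 8760 nM

In a functional assay on HT-1080 cells (Homo sapiens) for inhibition, read by MTT assay, with a stated time of 48 h (a higher number here means a weaker inhibitor, a lower number a stronger inhibitor), compound 1 gives 3650 nM, the lowest of the two numbers, with compound 2 as its nearest neighbour. Going by the values given here, the only measured step, a 2.4-fold higher number from compound 1 to compound 2 (0.38 log units; beyond the scatter), concerns 2,4,5-trimethoxyphenyl in place of 3,4,5-trimethoxyphenyl on an aromatic carbon and does not touch the chain on the amide-type nitrogen.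

Compound 3 `COc1cc(-c2nc3cc(/C=C4\SC(=O)N(Cc5cccc(C)c5)C4=O)ccc3[nH]2)cc(OC)c1OC` differs from compound 1 by 3-methylphenyl in place of (piperidin-1-yl)carbonyl on a saturated chain carbon bound to an amide-type nitrogen in a ring. Among the compounds with values here, no measured step bears on this change, so no direction beyond the scatter is supported; an unchanged number with a wide range is the working expectation.

Compound 3 is estimated at 3500 nM (range 1000 nM to 12000 nM), an expected step of a 1.0-fold lower number from compound 1 to compound 3 (0.02 log units; within the scatter).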

Compound 3, half-maximal inhibitory concentration: 4580 nM
Compound 3: middle estimate off by 1.3-fold (0.12 log units), on the low side; the measured number falls inside the stated range.
By their numbers in this assay, from the lowest: compounds 1, 3 and 2 (each within the scatter of the next, the first and the last beyond it).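

Going by these compounds alone, at the saturated chain carbon bound to an amide-type nitrogen in a ring, this assay gives the first reading of this position: a 1.3-fold higher number from compound 1 to compound 3 (0.10 log units; within the scatter) for 3-methylphenyl in place of (piperidin-1-yl)carbonyl. The two groups differ in ring type and hydrogen-bond acceptor count, yet the two compounds cannot be told apart here. No evidence on the origin of this result is available.

As far as these compounds go, a carboxylic acid or a longer chain in place of 3-methylbenzyl remains open. So does whether 2,4,5-trimethoxyphenyl would read the same alongside 3-methylbenzyl.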